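This account rests on a few compounds, and the source may have more. Where it says the series, first, only, none or still open, it means among the compounds named here.

Compound 1 `Cc1ccc(OCC(=O)N(Cc2cccs2)c2ccnn2C)cc1` was measured in an assay on HEK293 cells for agonist activity at transient receptor potential cation channel subfamily M member 8 (Homo sapiens), read by fluorescence and calcium flux, with a stated time of 15 min (a lower number here means that less compound is needed, a higher number that more compound is needed for the effect), where compound 1 gives 422 nM. For the measured compounds named here, that is the higher of the two numbers known so far: compound 2 `COc1ccc2oc(C(=O)N(Cc3cccs3)c3ccn[nH]3)cc2c1` gives 1.1 nM in this assay, a gap well beyond the usual scatter. Compound 3 `Cc1ccc(OCC(=O)N(Cc2cccs2)c2ccon2)cc1` has not yet been measured. Its difference from compound 1 is 1,2-oxazol-3-yl in place of 1-methyl-1H-pyrazol-5-yl on an amide-type nitrogen. Going by the values given here, no measured pair shows this exact change, so the step is expected to be a 1.2-fold higher number from compound 1 to compound 3 (0.07 log units; within the scatter), taken to lie within the scatter, with no clear direction. Compound 3 is therefore expected to give about 500 nM, between 150 nM and 2000 nM.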

Compound 3, half-maximal effective concentration: 2 nM
For compound 3 the middle estimate is 250-fold (2.40 log units) above the measured one, and the stated range ends above it.
By their numbers in this assay, from the lowest: compounds 2 and 3 (each within the scatter of the next); then compound 1.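

For the compounds shown here, the place on the amide-type nitrogen turns out to matter greatly on the core of compound 1: 1,2-oxazol-3-yl in place of 1-methyl-1H-pyrazol-5-yl gives a 210-fold lower number from compound 1 to compound 3 (2.32 log units; beyond the scatter), which no earlier pair could show. Both groups are single five-membered aromatic rings with the same counts of donors and acceptors, so those counts do not separate them. Nothing available explains the step.
Open, as far as these compounds go, is whether a pyridine ring or a phenyl ring at this place would keep the low number. Also open, from the compounds shown here alone, is whether the same change would act alike on the core of compound 2.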